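The source may hold more compounds than are shown below. What is called first, only, known or untested is meant among the compounds shown, and "the series" means these compounds.

Measured so far:
compound 1 `O=C(O)[C@H]1NC[C@H](O)[C@@H](O)[C@H]1O` — 31%
compound 2 `O=C(O)[C@@H]1NC[C@@H](O)[C@@H](O)[C@@H]1O` — 7.2%
compound 3 `O=C(O)[C@@H]1NCC=C[C@@H]1O` — 1.3%

In an assay for inhibition of alpha-N-acetylgalactosaminidase (Gallus gallus), tested at 1000 uM (a lower number here means less inhibition, a higher number more inhibition at the concentration tested (going by the name of the read-out)), compound 2 stands second highest of the three; compound 3 lies within the scatter of it, while compound 1 lies well above it. Compound 4 `O=C(O)[C@H]1NC[C@@H](O)[C@@H](O)[C@@H]1O` has not been measured. Compared with compound 2 the change is the two compounds have the same atoms and bonds and differ only in configuration as drawn: 1 of 4 stereo elements differ; a stereocentre at a saturated ring carbon is drawn R in compound 2 and S in compound 4. Within the data shown here, the only measured step that bears on configuration is a number 23.8 percentage points lower from compound 1 to compound 2 (beyond the scatter), where the fact that compounds 1 and 2 differ only in the configuration as drawn and three stereocentres changed at once. Here one stereocentre changes, so a smaller move is expected, and one configuration in compound 4 now matches compound 1. Compound 4 is expected to give 15%, between 2% and 35%; the expected step of a number 7.8 percentage points higher from compound 2 to compound 4 (within the scatter) is modest, upward, and may stay within the scatter.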

Compound 4, a percentage reported as inhibition, at one concentration (the size of the read-out at that concentration, not a potency): 3.8%
Compound 4: middle estimate off by 11.2 percentage points, on the high side, and the stated range covers the measured number.
By their numbers in this assay, from the lowest: compounds 3, 4 and 2 (each within the scatter of the next); then compound 1.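

In this assay changing only this one stereocentre gives a number 3.4 percentage points lower from compound 2 to compound 4 (within the scatter) and so, taken alone, does not bring inhibition back. Two differing stereocentres still leave a number 27.2 percentage points lower from compound 1 to compound 4 (beyond the scatter) and so, among these compounds, the higher reading goes with those two centres rather than with this one.

Which of those two centres matters more, or whether both are needed together, stays open. Also open, as far as these compounds go, is how an amine in place of one hydroxyl, or an amide in place of the carboxylic acid, would read.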